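This account rests on a few compounds, and the source may have more. Where it says the series, first, only, none or still open, it means among the compounds named here.

Measured so far:
- compound 1, `CC/N=C(\S)NCCCCCn1nc(-c2ccccc2)ccc1=O`: 51.8 mg/kg
- compound 2, `CC/N=C(/NC#N)NCCCCCn1nc(-c2ccccc2)ccc1=O`: 100 mg/kg

In a functional assay on the whole organism (stomach) with Rattus norvegicus as the target (a higher number here means that more compound is needed for the effect, a lower number that less compound is needed), compound 2 gives 100 mg/kg, the highest of the two numbers; its nearest neighbour is compound 1, and the gap a 1.9-fold higher number from compound 1 to compound 2 (0.29 log units; within the scatter) lies within the scatter, so the two cannot be ordered.

The next step goes from compound 2 to compound 3, `CN(C)/C(=N/CCCCCn1nc(-c2ccccc2)ccc1=O)NC#N`. The change is a group of 8 heavy atoms (4 carbon, 4 nitrogen; no ring) in place of a group of 8 heavy atoms (4 carbon, 4 nitrogen; no ring), on a saturated chain carbon, five bonds along the chain from an aromatic nitrogen: the same atoms are joined differently, the cyanoguanidine end being rebuilt with one donor fewer.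

Among the measured compounds shown here, no measured step tests such a rearrangement. For the measured compounds named here, the only step available, a 1.9-fold higher number from compound 1 to compound 2 (0.29 log units; within the scatter), exchanges a different group and itself stays within the scatter, so it offers no direction for the present change. On that basis no movement beyond the scatter is expected, and the step of no change at the digits printed from compound 2 to compound 3 (within the scatter) is an estimate of near-constancy.

Compound 3 is therefore expected to give about 100 mg/kg in this assay, within 40 mg/kg to 250 mg/kg.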

Compound 3, dose for half-maximal effect: 81.5 mg/kg
Beside the measured number, compound 3's estimate is 1.2-fold (0.09 log units) above it; low and high end bracket the measured number.
By their numbers in this assay, from the lowest: compounds 1, 3 and 2 (each within the scatter of the next).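

In this assay, rejoining the same atoms at the chain end, with 1 hydrogen-bond donor in the entering group against 2 in the group it replaces, gives a step that stays within the scatter (a 1.2-fold lower number from compound 2 to compound 3 (0.09 log units; within the scatter)). Among the compounds shown here, the earlier compounds offered no such rearrangement, so this is the first sign that this donor count and atom connectivity do not separate the compounds at this position in this whole-organism read-out. The step between the two groups not yet compared directly also stays within the scatter (a 1.6-fold higher number from compound 1 to compound 3 (0.20 log units; within the scatter)), so all three end groups remain unordered, and nothing available explains this flat result.

The compounds shown leave open whether an amine or a carboxylic acid at this position would give a step beyond the scatter. They also leave open whether a longer chain would do so.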